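The source may report more compounds than this note shows. Statements on the series, on what has been measured and on what is new or still open speak of the compounds shown alone.

Compound 1 `Cc1ccc2c(c1)/C(=N/N=C/c1ccco1)C(=O)N2`: in a functional assay on MCF7 cells (Homo sapiens) for cytotoxicity, read by sulforhodamine B assay, with a stated time of 48 h (a higher number here means a weaker inhibitor, a lower number a stronger inhibitor), compound 1 gives 8750 nM.
Compound 2 `O=C1Nc2ccc(Cl)cc2/C1=N/N=C/c1ccco1`: in this assay compound 2 gives 7750 nM.
Compound 3 `Cc1ccc2c(c1)/C(=N/N=C/c1ccc[nH]1)C(=O)N2`: in this assay compound 3 gives 9250 nM.

All three numbers sit close together. The change chloro in place of methyl on an aromatic carbon made a 1.1-fold lower number from compound 1 to compound 2 (0.05 log units; within the scatter). The two cores differ as 1H-pyrrol-2-yl in place of furan-2-yl on a carbon with a double bond to nitrogen, which made a 1.1-fold higher number from compound 1 to compound 3 (0.02 log units; within the scatter). Compound 2 and compound 3 are also within the scatter of each other.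

Compound 4 `O=C1Nc2ccc(Cl)cc2/C1=N/N=C/c1ccc[nH]1` has not yet been measured in this assay. It differs from compound 3 as chloro in place of methyl on an aromatic carbon; the place is described in the same words as for the earlier change, so the two changes are the same. On the core of compound 1 this change gave a step within the scatter, so for compound 4 a step of about a 1.1-fold lower number from compound 3 to compound 4 (0.05 log units; within the scatter) is expected, resting on compound 1 with 8750 nM and the step of a 1.1-fold lower number from compound 1 to compound 2 (0.05 log units; within the scatter). For compound 4 a value of about 8300 nM is estimated, between 4000 nM and 17000 nM.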

Compound 4, half-maximal inhibitory concentration: 11800 nM
Estimate against measurement, compound 4: 1.4-fold (0.15 log units) below; low and high end bracket the measured number.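

In this assay, chloro in place of methyl on an aromatic carbon gave a 1.3-fold higher number from compound 3 to compound 4 (0.11 log units; within the scatter), and this agrees with the same change on the other core: the same change on two cores in this assay, a 1.1-fold lower number (0.05 log units; within the scatter) from compound 1 to compound 2 and a 1.3-fold higher number (0.11 log units; within the scatter) from compound 3 to compound 4, 1.4-fold (0.16 log units) apart, within the scatter of two such steps. 1H-pyrrol-2-yl in place of furan-2-yl gave a 1.5-fold higher number from compound 2 to compound 4 (0.18 log units; within the scatter), and this change also carries across cores without a resolved difference: the same change on two cores in this assay, a 1.1-fold higher number (0.02 log units; within the scatter) from compound 1 to compound 3 and a 1.5-fold higher number (0.18 log units; within the scatter) from compound 2 to compound 4, 1.4-fold (0.16 log units) apart, within the scatter of two such steps. For the compounds shown here, every step here lies within the scatter, so the four compounds show only that neither change has a resolved effect on either core, and they do not show that a change with a larger effect would carry from one core to another.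

Still open, from the compounds shown here alone, is whether an amine or a carboxylic acid on that aromatic carbon would give a step beyond the scatter. Going by these compounds, it is also open whether such a step would hold on both cores.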